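A few compounds are considered here, and "the series" means these few. Any claim that something is new, unique, unknown or untested is made for them only; others in the source may bear on it.

Compound 1, `CCCCc1cn(C[C@H](O)[C@H]2OC(=O)C(OCc3ccccc3)=C2OCc2ccccc2)nn1`: 28600 nM
Compound 2, `CCCCCc1ccc(-c2cn(C[C@H](O)[C@H]3OC(=O)C(OCc4ccccc4)=C3OCc3ccccc3)nn2)cc1`: 6220 nM
Compound 3, `O=C1O[C@H]([C@@H](O)Cn2cc(C3CC3)nn2)C(OCc2ccccc2)=C1OCc1ccccc1`: 43900 nM

These three compounds share one core and differ only in the group carried on an aromatic carbon of the five-membered ring. In a functional assay on A549 cells (Homo sapiens) for antiproliferative activity, read by MTT assay, with a stated time of 72 h (on this read-out lower numbers stand for stronger inhibition and higher numbers for weaker inhibition), compound 3 gives the highest number of the three. Its nearest neighbour is compound 1, and the step of a 1.5-fold higher number from compound 1 to compound 3 (0.19 log units; within the scatter) lies within the scatter; the step of a 7.1-fold higher number from compound 2 to compound 3 (0.85 log units; beyond the scatter) lies beyond it.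

Compound 4, `O=C1O[C@H]([C@@H](O)Cn2cc(CNS(=O)(=O)c3ccc(Cl)cc3)nn2)C(OCc2ccccc2)=C1OCc1ccccc1`, differs from compound 3 by (((4-chlorophenyl)sulfonyl)amino)methyl in place of cyclopropyl on an aromatic carbon. Among the measured compounds shown here, two measured steps bear on this. The step of a 4.6-fold lower number from compound 1 to compound 2 (0.66 log units; beyond the scatter) shows a lower number when a small carbon chain gives way to a group holding a six-membered aromatic ring, and the step of a 7.1-fold higher number from compound 2 to compound 3 (0.85 log units; beyond the scatter) shows the reverse. For the measured compounds named here, because a 7.1-fold higher number from compound 2 to compound 3 (0.85 log units; beyond the scatter) runs from an aromatic-bearing group to the cyclopropyl, the opposite move in compound 4 is expected to lower the number again, though the entering group also carries a sulfonyl and an amino part that no measured compound holds, so the expectation is less firm: the expected step is a 4.9-fold lower number from compound 3 to compound 4 (0.69 log units; beyond the scatter). Compound 4 is therefore estimated at 9000 nM, with a range from 2500 nM to 30000 nM.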

Compound 4, half-maximal inhibitory concentration: 2870 nM
Beside the measured number, compound 4's estimate is 3.1-fold (0.50 log units) above it; low and high end bracket the measured number.
By their numbers in this assay, from the lowest: compound 4; then compound 2; then compounds 1 and 3 (each within the scatter of the next).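

In this assay this position on the five-membered ring accepts a much larger group with a sulfonyl and an amino part, giving a 15-fold lower number from compound 3 to compound 4 (1.18 log units; beyond the scatter) and a 10-fold lower number from compound 1 to compound 4 (1.00 log units; beyond the scatter). Even set against the 4-pentylphenyl group there is a 2.2-fold lower number from compound 2 to compound 4 (0.34 log units; beyond the scatter), so among these four compounds the two whose group holds a six-membered aromatic ring give the lower numbers, yet that ring alone does not fix the number. No measured evidence explains the change at this position.

On these data alone, it remains open whether the chlorine, the sulfonyl or the amino part accounts for the lower number. A plain aminomethyl group, a phenylsulfonyl group without the chlorine, or a carbonyl in place of the sulfonyl would begin to separate these parts.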